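The source may report more compounds than this note shows. Statements on the series, on what has been measured and on what is new or still open speak of the compounds shown alone.

Measured so far in an ADME assay on microsomes from liver (Rattus norvegicus) for metabolic stability; a lower number here means that the compound disappears faster, a higher number that the compound lasts longer:
- Compound 1 `CC#C[C@@H](Cc1nnn[nH]1)c1ccc(OCc2ccc3sc(F)c(-c4ccccc4C)c3c2)cc1`: 0.367 h
- Compound 2 `CC#C[C@@H](Cc1nnn[nH]1)c1ccc(OCc2ccc3scc(-c4cc(OCCOC)ccc4C)c3c2)cc1`: 0.367 h
- Compound 3 `CC#C[C@@H](Cc1nnn[nH]1)c1ccc(OCc2ccc3sc(C#N)c(-c4ccccc4C)c3c2)cc1`: 0.533 h

Compound 2, at 0.367 h, sits level with compound 1 and within the scatter of compound 3. The next structure, compound 4 `CC#C[C@@H](Cc1nnn[nH]1)c1ccc(OCc2ccc3scc(C4CC4)c3c2)cc1`, carries cyclopropyl in place of 5-(2-methoxyethoxy)-2-methylphenyl on an aromatic carbon. Among the measured compounds shown here, no measured step makes this change. For the measured compounds named here, the only step available, a 1.5-fold higher number from compound 1 to compound 3 (0.16 log units; within the scatter), is a different swap that stays within the scatter, so it offers weak guidance. No direction can be argued from it, and no shift beyond the scatter is expected, though uncertainty remains wide. The estimated step is a 1.2-fold higher number from compound 2 to compound 4 (0.09 log units; within the scatter). For compound 4 the expected value is 0.45 h, with an estimated range of 0.2 h to 1 h.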

Compound 4, half-life: 1.72 h
Compound 4: middle estimate off by 3.8-fold (0.58 log units), on the low side; measured number above the stated range.
By their numbers in this assay, from the lowest: compounds 1, 2 and 3 (each within the scatter of the next); then compound 4.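

In this assay, among the compounds shown here, the position two ring bonds from the ring sulfur proves able to move the number: cyclopropyl in place of 5-(2-methoxyethoxy)-2-methylphenyl gives a 4.7-fold higher number from compound 2 to compound 4 (0.67 log units; beyond the scatter) and is the first step here beyond the scatter. The swap takes away 12 heavy atoms and puts in 3, so a large group is not needed at this carbon for the compound to last longer. Nothing available explains the rise. Still open, on these data alone, is whether the cyclopropyl ring itself matters or only the loss of the larger group; a methyl group or a cyclopentyl ring on this carbon would help separate the two.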